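A few compounds are considered here, and "the series" means these few. Any claim that something is new, unique, unknown or untested is made for them only; others in the source may bear on it.

Compound 1, with the structure `CC(C)(C(=O)c1ccccc1)c1cccnc1`, carries a carbonyl flanked by a phenyl group on one side and a saturated chain carbon bearing two methyl groups and a pyridine ring on the other. In a functional assay for inhibition of cytochrome P450 11B1, mitochondrial (Bos taurus) (a lower number here means a stronger inhibitor, a higher number a weaker inhibitor), compound 1 gives 3300 nM. That is the highest of the two numbers recorded here. The nearest neighbour is compound 2, with the structure `CC(C)(c1cccnc1)C(O)c1ccccc1`, in which the carbonyl of compound 1 has become a hydroxyl-bearing carbon; in this assay compound 2 gives 1530 nM, a lower number than compound 1 by a gap that lies beyond the usual scatter.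

Compound 3, with the structure `CC(C(=O)c1ccccc1)c1cccnc1`, has not yet been measured. It differs from compound 1 in one place: hydrogen in place of methyl on a saturated chain carbon bound to an aromatic carbon, a carbonyl carbon and a saturated chain carbon. Among the compounds with values here, no measured pair shows what removing such a methyl does, so no step size can be read from the data. The change is small and leaves the carbonyl and both rings untouched, so the step from compound 1 to compound 3 is expected to be modest, a 1.3-fold lower number from compound 1 to compound 3 (0.12 log units; within the scatter), and in either direction at most little beyond the scatter. Compound 3 is therefore expected to give about 2500 nM in this assay, with a likely range from 800 nM to 8000 nM.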

Compound 3, half-maximal inhibitory concentration: 7720 nM
For compound 3 the middle estimate is 3.1-fold (0.49 log units) below the measured one, within the range that was stated.
By their numbers in this assay, from the lowest: compound 2; then compound 1; then compound 3.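

In this assay, leaving hydrogen in place of methyl on the saturated chain carbon bound to an aromatic carbon, a carbonyl carbon and a saturated chain carbon gives a 2.3-fold higher number from compound 1 to compound 3 (0.37 log units; beyond the scatter). Compounds 1 and 2 both keep the two methyl groups on this carbon, and they do not show whether this position matters. Now it is clear that losing a single carbon atom, with no ring, hydrogen-bond donor, hydrogen-bond acceptor or charge involved, is enough to make the inhibitor weaker by a step beyond the usual scatter. The data shown offer no measurement that explains why this methyl counts.

As far as these compounds go, whether a longer chain such as ethyl in place of methyl on this carbon would bring the number below that of compound 1, or whether hydrogen in place of the remaining methyl would raise it further, stays open. From the compounds shown here alone, this is also a single pair with a carbonyl in the core, so it remains unknown whether removing the same methyl would have a similar effect on compound 2, which has a hydroxyl-bearing carbon there instead.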